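Thiazolidine amides with a long alkyl chain: aryl variation

The source may hold more compounds than are shown below. What is called first, only, known or untested is meant among the compounds shown, and "the series" means these compounds.

The series shares the core of compound 1 `CCCCCCCCCCCCCCCCCCNC(=O)[C@@H]1CSC(c2cc(OC)c(OC)c(OC)c2)N1`, which carries a 3,4,5-trimethoxyphenyl group and in a functional assay on LNCaP cells (Homo sapiens) for antiproliferative activity, read by sulforhodamine B assay (on this read-out higher numbers stand for weaker inhibition and lower numbers for stronger inhibition), gives 820 nM. Compound 2 `CCCCCCCCCCCCCCCCCCNC(=O)[C@@H]1CSC(c2ccc(O)cc2)N1` carries a 4-hydroxyphenyl group instead; in this assay compound 2 gives 1600 nM, the highest of the two numbers recorded so far, though a 2.0-fold higher number from compound 1 to compound 2 (0.29 log units; within the scatter), so the two compounds cannot be ordered. Compound 3 `CCCCCCCCCCCCCCCCCCNC(=O)[C@@H]1CSC(c2c(OC)cc(OC)cc2OC)N1` is not yet measured. It differs from compound 2 by 2,4,6-trimethoxyphenyl in place of 4-hydroxyphenyl on a saturated ring carbon. For the measured compounds named here, the only step that bears on this change is the one from the trimethoxy to the hydroxy aryl, which stayed within the scatter, so no step beyond the scatter is expected here either; if anything, a return toward the value of compound 1 seems plausible. This expectation amounts to a 1.6-fold lower number from compound 2 to compound 3 (0.20 log units; within the scatter). Compound 3 is therefore expected to give 1000 nM, with a range from 400 nM to 3000 nM.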

Compound 3, half-maximal inhibitory concentration: 2400 nM
Compound 3: the middle estimate sits 2.4-fold (0.38 log units) below what was measured, and the stated range covers the measured number.
By their numbers in this assay, from the lowest: compounds 1, 2 and 3 (each within the scatter of the next, the first and the last beyond it).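

In this assay, for the compounds shown here, the move from 3,4,5-trimethoxyphenyl to 2,4,6-trimethoxyphenyl gives a 2.9-fold higher number from compound 1 to compound 3 (0.47 log units; beyond the scatter) and is the first step at this saturated ring carbon to clear the scatter, though only modestly; since the two groups differ only in where the methoxy groups stand, their placing on the phenyl ring matters here, not just their presence. The other change gives a 1.5-fold higher number from compound 2 to compound 3 (0.18 log units; within the scatter) and so leaves 4-hydroxyphenyl and 2,4,6-trimethoxyphenyl unordered, despite the difference in heavy atoms and hydrogen-bond donors. No supporting data are available to explain either result.

Still open, from the compounds shown here alone, is how an amine or a carboxylic acid on the phenyl ring would read in this assay. Also open, going by these compounds, is whether a shorter chain in place of the long alkyl chain would keep these numbers.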